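A Benzyl Swap on Compound 1

This account rests on a few compounds, and the source may have more. Where it says the series, first, only, none or still open, it means among the compounds named here.

In a functional assay on MCF7 cells (Homo sapiens) for cytotoxicity, read by MTT assay, with a stated time of 24 h (a higher number here means a weaker inhibitor, a lower number a stronger inhibitor), compound 1 (`COc1ccc(/C=C2\CN(C(=S)SCc3cn(Cc4ccccc4F)nn3)C/C(=C\c3ccc(OC)cc3)C2=O)cc1`) gives 79400 nM as the highest of the two true numbers obtained so far. Compound 2 (`O=C1/C(=C/c2ccccc2F)CN(Cc2cn(Cc3ccccc3F)nn2)C/C1=C\c1ccccc1F`) gives 6000 nM in the same test, a number lower than that of compound 1 by more than the usual scatter. Compound 3 (`Cc1ccc(/C=C2\CN(C(=S)SCc3cn(Cc4ccccc4F)nn3)C/C(=C\c3ccc(C)cc3)C2=O)cc1`) is reported only as a limit of > 100000 nM and not as a number.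

Compound 4 (`COc1ccc(/C=C2\CN(C(=S)SCc3cn(Cc4cccc(Cl)c4)nn3)C/C(=C\c3ccc(OC)cc3)C2=O)cc1`) keeps the core of compound 1 and alters a single group (3-chlorophenyl in place of 2-fluorophenyl on a saturated chain carbon bound to an aromatic nitrogen). In words, 3-chlorophenyl stands in place of 2-fluorophenyl on a saturated chain carbon bound to an aromatic nitrogen, which also reads as 2-fluorobenzyl to 3-chlorobenzyl. All three measured compounds carry the 2-fluorobenzyl group, so the data hold no direct measure of this change. With compound 1 at 79400 nM as the only close anchor, no step beyond the scatter is expected in this assay in either direction. The estimated move a 1.2-fold lower number from compound 1 to compound 4 (0.09 log units; within the scatter) is expected to stay within the usual scatter. Compound 4 is estimated at 65000 nM (expected range 25000 nM to 100000 nM).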

Compound 4, half-maximal inhibitory concentration: 32000 nM
Beside the measured number, compound 4's estimate is 2.0-fold (0.31 log units) above it, within the range that was stated.
By their numbers in this assay, from the lowest: compound 2; then compound 4; then compound 1. At a limit, above all of these: compound 3.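

In this assay, the change from 2-fluorobenzyl to 3-chlorobenzyl gives a 2.5-fold lower number from compound 1 to compound 4 (0.39 log units; beyond the scatter), the first measure of this position, as every earlier compound carried the 2-fluorobenzyl group. The step is modest, but it shows that the number responds to the group on a saturated chain carbon bound to an aromatic nitrogen while the core of compound 1 stays the same, so this position is not silent in this test. Compound 3, which also carries the 2-fluorobenzyl group, is held at a limit and not a number, so it offers no second measure of how far this group sets the reading: the limit of > 100000 nM in this assay, at which 1 of the 4 values shown sits.

The two group names differ both in the halogen and in its number on the ring, and no compound shown separates these two parts of the change, so the step cannot be assigned to either one. Also open, going by these compounds, is whether a plain benzyl group, or a benzyl group carrying an amine or a carboxylic acid, would move the number further, and whether the same swap gives a similar step on any other core.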